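Extending the biphenyl tail with an acid-bearing phenoxy group

The source may report more compounds than this note shows. Statements on the series, on what has been measured and on what is new or still open speak of the compounds shown alone.

Compound 1 `Cc1ccccc1-n1nc(C)c2c1NC(=O)[C@H](C)S[C@@H]2c1ccc(-c2ccccc2)cc1` is tested in an assay on isolated protein for agonist activity at Bile acid receptor (Homo sapiens), read by AlphaScreen, with a stated time of 30 min (on this read-out higher numbers stand for an effect only at larger amounts of compound and lower numbers for an effect already at smaller amounts), where compound 1 gives 990 nM. Compound 2 `CCc1ccccc1-n1nc(C)c2c1NC(=O)[C@H](C)S[C@@H]2c1ccc(Oc2ccccc2)cc1` gives 1100 nM in this assay, so the two numbers lie within the usual scatter of each other and neither can be set apart. Compound 3 `Cc1ccccc1-n1nc(C)c2c1NC(=O)[C@H](C)S[C@@H]2c1ccc(Oc2cccc(C(=O)O)c2)cc1` has not been measured yet; it differs from compound 1 by 3-carboxyphenoxy in place of phenyl on an aromatic carbon. Going by the values given here, no measured step shows this kind of change, so the expectation rests on the structures alone. A moderate gain in this assay is expected, with the step from compound 1 to compound 3 estimated at a 3.3-fold lower number from compound 1 to compound 3 (0.52 log units; beyond the scatter). Compound 3 is therefore expected to give about 300 nM, between 60 nM and 1500 nM.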

Compound 3, half-maximal effective concentration: "not active" (no number reported)
No number was reported for compound 3; there is nothing to compare the estimate with.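

Going by these compounds alone, compound 3 was reported as "not active" with no number, so no step from compound 1 to compound 3 can be read. The compounds shown leave open how much the 3-carboxyphenoxy group contributes to this outcome. Nothing available explains the result.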